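The source may report more compounds than this note shows. Statements on the series, on what has been measured and on what is new or still open speak of the compounds shown alone.

Three pyrazoline amides have been measured, and a fourth awaits its number. Compound 2, `O=C(C1COc2ccccc2O1)N1N=C(c2ccc(Br)cc2)CC1c1ccc(F)cc1`, is the anchor of the set: in a functional assay on WM 266-4 cells (Homo sapiens) for inhibition, read by MTT assay, with a stated time of 24 h (on this read-out lower numbers stand for stronger inhibition of growth and higher numbers for weaker inhibition of growth), compound 2 gives 5630 nM. Compound 1, `O=C(C1COc2ccccc2O1)N1N=C(c2ccc(Br)cc2)CC1c1ccccc1F`, carries the change (2-fluorophenyl in place of 4-fluorophenyl on a saturated ring carbon); in this assay compound 1 gives 8030 nM, which is a 1.4-fold higher number from compound 2 to compound 1 (0.15 log units; within the scatter). Compound 3, `O=C(c1ccc2c(c1)OCCO2)N1N=C(c2ccc(Br)cc2)CC1c1ccc(F)cc1`, keeps the aryl group of compound 2 but differs in the core, namely (2,3-dihydro-1,4-benzodioxin-6-yl in place of 2,3-dihydro-1,4-benzodioxin-2-yl on a carbonyl carbon); in this assay compound 3 gives 3260 nM, which is a 1.7-fold lower number from compound 2 to compound 3 (0.24 log units; within the scatter).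

Compound 4, `O=C(c1ccc2c(c1)OCCO2)N1N=C(c2ccc(Br)cc2)CC1c1ccccc1F`, is the one not yet measured. It differs from compound 3 by 2-fluorophenyl in place of 4-fluorophenyl on a saturated ring carbon, and the surroundings of the place are the same as for the change from compound 2 to compound 1, so it is the same change, seen a second time in the set. Among the compounds with values here, for compound 4 the expected step is a 1.4-fold higher number from compound 3 to compound 4 (0.14 log units; within the scatter), set beside the earlier step because a 1.4-fold higher number from compound 2 to compound 1 (0.15 log units; within the scatter) is the only measured instance of this change. On that basis compound 4 is expected to give 4500 nM in this assay, with a likely range from 2400 nM to 8500 nM.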

Compound 4, concentration for 50% growth inhibition: 580 nM
The estimate for compound 4 lay 7.8-fold (0.89 log units) above the measured number, outside the stated range (below it).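

Placing 2-fluorophenyl in place of 4-fluorophenyl on the saturated ring carbon gives a 5.6-fold lower number from compound 3 to compound 4 (0.75 log units; beyond the scatter) in this assay, so this change does not carry over from one core to the other with the same size: the same change on two cores in this assay, a 1.4-fold higher number (0.15 log units; within the scatter) from compound 2 to compound 1 and a 5.6-fold lower number (0.75 log units; beyond the scatter) from compound 3 to compound 4, 8.0-fold (0.90 log units) apart, beyond the scatter of two such steps Read the other way, 2,3-dihydro-1,4-benzodioxin-6-yl in place of 2,3-dihydro-1,4-benzodioxin-2-yl on the carbonyl carbon gives a 14-fold lower number from compound 1 to compound 4 (1.14 log units; beyond the scatter), so the size of this step also depends on the aryl group present: the same change on two cores in this assay, a 1.7-fold lower number (0.24 log units; within the scatter) from compound 2 to compound 3 and a 14-fold lower number (1.14 log units; beyond the scatter) from compound 1 to compound 4, 8.0-fold (0.90 log units) apart, beyond the scatter of two such steps These four compounds show that the two changes do not simply add up in this pair of cores, but they do not show why, nor whether the same holds for any other core or read-out.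

From the compounds shown here alone, it remains open whether the low number of compound 4 is tied to fluorine itself or would also appear with 2-chlorophenyl, 2-methoxyphenyl or plain phenyl on that carbon. Going by these compounds, it is equally open whether it survives replacing the 4-bromophenyl group with 4-chlorophenyl.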